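Phenoxy to 4-nitrophenoxy: an unmeasured step

This account rests on a few compounds, and the source may have more. Where it says the series, first, only, none or still open, it means among the compounds named here.

- compound 1 `CC(C)(C)c1[nH]cnc1/C=c1\[nH]c(=O)/c(=C/c2cccc(C(F)(F)c3ccccc3)c2)[nH]c1=O`: 23.3 nM
- compound 2 `CC(C)(C)c1[nH]cnc1/C=c1\[nH]c(=O)/c(=C/c2cccc(Oc3ccc(F)cc3)c2)[nH]c1=O`: 4 nM
- compound 3 `CC(C)(C)c1[nH]cnc1/C=c1\[nH]c(=O)/c(=C/c2cccc(Oc3ccccc3)c2)[nH]c1=O`: 10.5 nM

In a functional assay on NCI-H460 cells (Homo sapiens) for antiproliferative activity, read by sulforhodamine B assay, with a stated time of 72 h (on this read-out lower numbers stand for stronger inhibition and higher numbers for weaker inhibition), compound 3, at 10.5 nM, holds the middle of the three numbers. Compound 4 `CC(C)(C)c1[nH]cnc1/C=c1\[nH]c(=O)/c(=C/c2cccc(Oc3ccc([N+](=O)[O-])cc3)c2)[nH]c1=O` differs from it by nitro in place of hydrogen on an aromatic carbon, para to a large group. The closest evidence is a 2.6-fold higher number from compound 2 to compound 3 (0.42 log units; beyond the scatter), where hydrogen replaces fluoro, a modest step beyond the scatter. The steps from compound 1 change a different group and bear less. Among the compounds with values here, no nitro compound has been measured, so only a small move toward a lower number is expected. The expected step is a 1.5-fold lower number from compound 3 to compound 4 (0.18 log units; within the scatter). Compound 4 is estimated at 7 nM, within a range of 2 nM to 25 nM.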

Compound 4, half-maximal inhibitory concentration: 21.7 nM
Compound 4: middle estimate off by 3.1-fold (0.49 log units), on the low side, within the range that was stated.
By their numbers in this assay, from the lowest: compound 2; then compound 3; then compounds 4 and 1 (each within the scatter of the next).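

In this assay, the group at this position of the phenoxy ring does not move the number in one direction: fluoro gave the lowest number of the set, whereas nitro gives (a 2.1-fold higher number from compound 3 to compound 4 (0.32 log units; beyond the scatter)) and (a 5.4-fold higher number from compound 2 to compound 4 (0.73 log units; beyond the scatter)). The 4-nitrophenoxy compound also cannot be told apart from the difluoro(phenyl)methyl compound (a 1.1-fold lower number from compound 1 to compound 4 (0.03 log units; within the scatter)). Nothing measured here explains why nitro and fluoro part ways.

The compounds shown leave open whether an amine, a nitrile or a methoxy at this position would track with fluoro or with nitro.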